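The source may hold more compounds than are shown below. What is called first, only, known or untested is meant among the compounds shown, and "the series" means these compounds.

In a toxicity assay (RAW264.7 cells) for cytotoxicity, with Mus musculus as the target, read by MTT assay, with a stated time of 4 h (a lower number here means a stronger inhibitor, a higher number a weaker inhibitor), compound 1, `O=c1oc2cc(O)cc(O)c2cc1-c1ccccc1`, gives only a limit of the assay, > 100000 nM. Compound 2, `O=c1oc2cc(O)cc(O)c2cc1-c1cccc(O)c1`, likewise gives only a limit in this assay, > 100000 nM. Compound 2 differs from compound 1 by hydroxy in place of hydrogen on an aromatic carbon; the step that the two limits leave unreadable from compound 1 to compound 2 cannot be read because of the limit of > 100000 nM in this assay, at which 2 of the 3 values shown sit. For the measured compounds named here, compound 3, `O=c1oc2c(O)c(O)ccc2cc1-c1cccc(O)c1`, is the one compound that gives a number in this assay, 398000 nM. How the core of compound 3 differs from that of compound 1 is not broken down here. Compound 4, `O=c1oc2c(O)c(O)ccc2cc1-c1ccc(O)c(O)c1`, is not yet measured; it differs from compound 3 by hydroxy in place of hydrogen on an aromatic carbon. This is the same kind of change as that from compound 1 to compound 2, but here the entering hydroxy stands ortho to a hydroxy group and para to a large group, where in compound 2 it stands meta to a large group. Since the earlier step that the two limits leave unreadable from compound 1 to compound 2 left no readable size, the step from compound 3 to compound 4 is expected to be small, a 1.3-fold lower number from compound 3 to compound 4 (0.12 log units; within the scatter). Compound 4 is therefore estimated at 300000 nM, between 100000 nM and 1000000 nM, with a fair chance that this assay again reports only a limit.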

Compound 4, half-maximal inhibitory concentration: 97500 nM
For compound 4 the middle estimate is 3.1-fold (0.49 log units) above the measured one; measured number below the stated range.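

In this assay, hydroxy in place of hydrogen on an aromatic carbon of the core of compound 3, ortho to a hydroxy group and para to a large group, gives a 4.1-fold lower number from compound 3 to compound 4 (0.61 log units; beyond the scatter), a modest step and the only readable size for this change in the series. On these data alone, the same kind of change on the core of compound 1 gives a step that cannot be read, so no size can be set beside the new one, and the transfer from one core to the other remains untested: the limit of > 100000 nM in this assay, at which 2 of the 4 values shown sit. The new step therefore shows that this change can lower the number on one core, but not that it does so on another core, and the entering hydroxy also stands in a different place in compound 2.

The compounds shown leave open whether a methoxy group, an amine or a fluorine in the same place would give a step of similar size. They also leave open what a hydroxy would do at other places on the core of compound 3.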